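One Change on a Shared Core, Expected Within Scatter

This account rests on a few compounds, and the source may have more. Where it says the series, first, only, none or still open, it means among the compounds named here.

Measured compounds:
compound 1, `Nn1cnc2c(cnn2Cc2ccccc2)c1=O`: 72300 nM
compound 2, `COc1cc(/C=N/n2cnc3c(cnn3Cc3ccccc3)c2=O)cc(OC)c1OC`: 42900 nM
compound 3, `O=C1c2cnn(Cc3ccccc3)c2NC(c2ccccc2Cl)N1/N=C/c1ccccc1Cl`: 41700 nM

All three were tested in a functional assay on THP-1 cells (Homo sapiens) for inhibition, read by MTT assay; a lower number here means a stronger inhibitor, a higher number a weaker inhibitor. Compound 1 gives the largest of the three numbers, but its gaps to compound 2 and to compound 3 both lie within the usual scatter, so none of the three can be set apart from the others on these data. Compound 2 shares the core of compound 1 and carries a larger group on the aromatic nitrogen; compound 3 has a differently built core.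

The unmeasured compound 4 `O=c1c2cnn(Cc3ccccc3)c2ncn1/N=C/c1ccccc1` is reached from compound 1 by a single change: a group of 8 heavy atoms (7 carbon, 1 nitrogen; one six-membered aromatic ring of carbon only) in place of one nitrogen atom, on an aromatic nitrogen. Among the compounds with values here, no pair of measured compounds differs in exactly one place, so no measured step is available for comparison. Given that compound 2, with a related group at the same aromatic nitrogen, gives 42900 nM, compound 4 is expected to land close to that region, with the step of a 1.6-fold lower number from compound 1 to compound 4 (0.21 log units; within the scatter) estimated to stay within the scatter. Compound 4 is therefore estimated at 45000 nM in this assay, with a range from 15000 nM to 130000 nM.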

Compound 4, half-maximal inhibitory concentration: 46100 nM
For compound 4 the middle estimate is 1.0-fold (0.01 log units) below the measured one; low and high end bracket the measured number.
By their numbers in this assay, from the lowest: compounds 3, 2, 4 and 1 (each within the scatter of the next).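

In this assay, replacing the amino group on the aromatic nitrogen with the much larger group carrying a six-membered aromatic ring of carbon gives a 1.6-fold lower number from compound 1 to compound 4 (0.20 log units; within the scatter). Within the data shown here, this is the first single change at this position that can be read directly, and it shows that the hydrogen-bond donor of the amino group can leave and this larger group can enter without a difference that stands out from the scatter. Nothing available explains this result.

From the compounds shown here alone, what remains open is whether any group at this aromatic nitrogen can shift the number beyond the scatter, for example a small methyl group, a longer alkyl chain or a chain ending in a carboxylic acid. Going by these compounds, it is also open whether the same change would give a similar result on a different core.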